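This account rests on a few compounds, and the source may have more. Where it says the series, first, only, none or still open, it means among the compounds named here.

Three compounds of the series have a number in a functional assay on HT-29 cells (Homo sapiens) for cytotoxicity, with a stated time of 4 h; on this read-out lower numbers stand for stronger inhibition and higher numbers for weaker inhibition. Compound 1, `CN(C)CCNc1n[n+]([O-])c2ccc(C(C)(C)C)cc2[n+]1[O-]`, gives 3700 nM. Compound 2, `CC(C)(C)c1ccc2c(c1)[n+]([O-])c(NCCN1CCCCC1)n[n+]2[O-]`, gives 4000 nM. Compound 3, `CCOc1ccc2c(c1)[n+]([O-])c(NCCN(C)C)n[n+]2[O-]`, gives 2600 nM, the lowest of the three, with its nearest neighbour compound 1.

Compound 1 and compound 2 share a core and differ only by piperidin-1-yl in place of dimethylamino on a saturated chain carbon, two bonds along the chain from a nitrogen on an aromatic ring; the step made by this change is a 1.1-fold higher number from compound 1 to compound 2 (0.03 log units; within the scatter). Compound 3 carries a different core, the difference being (ethoxy in place of tert-butyl on an aromatic carbon), and the step between the two cores is a 1.4-fold lower number from compound 1 to compound 3 (0.15 log units; within the scatter).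

Compound 4, `CCOc1ccc2c(c1)[n+]([O-])c(NCCN1CCCCC1)n[n+]2[O-]`, is not yet measured in this assay. It stands to compound 3 as compound 2 stands to compound 1, the change being (piperidin-1-yl in place of dimethylamino on a saturated chain carbon, two bonds along the chain from a nitrogen on an aromatic ring), the same change, at the same place. Among the measured compounds shown here, the only precedent for it on this read-out is the step from compound 1 to compound 2, which lay within the scatter. The estimate for compound 4 is therefore a step of a 1.2-fold higher number from compound 3 to compound 4 (0.06 log units; within the scatter), expected to be no larger than the earlier step, because a 1.1-fold higher number from compound 1 to compound 2 (0.03 log units; within the scatter) came from the identical change. Compound 4 is expected to give about 3000 nM in this assay, within 1500 nM to 6000 nM, as the estimate.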

Compound 4, half-maximal inhibitory concentration: 2200 nM
Beside the measured number, compound 4's estimate is 1.4-fold (0.13 log units) above it; measured number inside the range.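

Piperidin-1-yl in place of dimethylamino carries over between the two cores in this assay, the new case being a 1.2-fold lower number from compound 3 to compound 4 (0.07 log units; within the scatter), and the two cases agree: the same change on two cores in this assay, a 1.1-fold higher number (0.03 log units; within the scatter) from compound 1 to compound 2 and a 1.2-fold lower number (0.07 log units; within the scatter) from compound 3 to compound 4, 1.3-fold (0.11 log units) apart, within the scatter of two such steps

Ethoxy in place of tert-butyl behaves likewise, the new case being a 1.8-fold lower number from compound 2 to compound 4 (0.26 log units; within the scatter), and again the two cases agree: the same change on two cores in this assay, a 1.4-fold lower number (0.15 log units; within the scatter) from compound 1 to compound 3 and a 1.8-fold lower number (0.26 log units; within the scatter) from compound 2 to compound 4, 1.3-fold (0.11 log units) apart, within the scatter of two such steps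

Among the compounds shown here, all four steps lie within the scatter, so the agreement is only one of steps too small to read on a single pair of cores, and it does not show how a change with a step beyond the scatter would carry from one core to another.

Still open, on these data alone, is whether a morpholin-4-yl or pyrrolidin-1-yl group in place of piperidin-1-yl, or a longer chain than 2-(piperidin-1-yl)ethyl, would move the number beyond the scatter. The same question stands for a methoxy group or a chlorine atom in place of ethoxy on the aromatic carbon.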